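The source may report more compounds than this note shows. Statements on the series, on what has been measured and on what is new or still open speak of the compounds shown alone.

Within the data shown here, compound 3 `CCCCCCCCCCCCCCNC(=O)[C@@H](NC(=O)c1cccs1)[C@@H](C)O` gives 36100 nM in a functional assay on MCF7 cells (Homo sapiens) for cytotoxicity, read by MTT assay, with a stated time of 48 h (on this read-out lower numbers stand for stronger inhibition and higher numbers for weaker inhibition), and stands second highest of the three numbers measured so far. Compound 2 `CCCCCCCCCCCCNC(=O)[C@@H](NC(=O)c1cccs1)[C@@H](C)O` gives 30400 nM, and compound 1 `CCCCCCCCNC(=O)[C@@H](NC(=O)c1cccs1)[C@@H](C)O` gives 72500 nM. All three measured steps concern the saturated chain only: a 2.4-fold lower number from compound 1 to compound 2 (0.38 log units; beyond the scatter), a 2.0-fold lower number from compound 1 to compound 3 (0.30 log units; within the scatter) and a 1.2-fold higher number from compound 2 to compound 3 (0.07 log units; within the scatter). Compound 4 `CCCCCCCCCCCCCCNC(=O)[C@@H](NS(=O)(=O)c1cccs1)[C@@H](C)O` differs from compound 3 in a different place: (thiophen-2-yl)sulfonyl in place of (thiophen-2-yl)carbonyl on an amine nitrogen. Among the measured compounds shown here, none of the measured steps touches this exchange, so the measured series offers no guide to its direction or size. Compound 4 is therefore expected to come out near compound 3, with an expected step of a 1.1-fold higher number from compound 3 to compound 4 (0.04 log units; within the scatter) and no direction beyond the scatter. The estimate for compound 4 is 40000 nM, with a range from 15000 nM to 110000 nM.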

Compound 4, half-maximal inhibitory concentration: 18700 nM
For compound 4 the middle estimate is 2.1-fold (0.33 log units) above the measured one, within the range that was stated.
By their numbers in this assay, from the lowest: compounds 4, 2, 3 and 1 (each within the scatter of the next, the first and the last beyond it).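

In this assay, putting (thiophen-2-yl)sulfonyl in place of (thiophen-2-yl)carbonyl on the amine nitrogen gives a 1.9-fold lower number from compound 3 to compound 4 (0.29 log units; within the scatter). Among these compounds, this is the first change away from the saturated chain, and it shows that this position accepts the sulfonyl group, with its extra double bond outside the ring, without a difference that stands clear of repeat measurements. No supporting measurement bears on this result. Going by these compounds, whether a phenyl group in place of thiophen-2-yl, or a urea on that nitrogen, would move the number beyond the scatter remains open. So does whether the same exchange behaves alike on the shorter chains of compound 1 and compound 2.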